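Replacing the chloro of compound 1 with a benzyloxyethoxy chain

A few compounds are considered here, and "the series" means these few. Any claim that something is new, unique, unknown or untested is made for them only; others in the source may bear on it.

The shared core carries a trimethoxyphenyl sulfide on an indole, and three variants of it have been measured in a functional assay on MCF7 cells (Homo sapiens) for inhibition, with a stated time of 48 h; a lower number here means a stronger inhibitor, a higher number a weaker inhibitor. Compound 1, `COc1cc(Sc2c[nH]c3ccc(Cl)cc23)cc(OC)c1OC`, gives 77 nM, the lowest of the three numbers. Compound 2, `COc1cc(Sc2c[nH]c3ccc(N)cc23)cc(OC)c1OC`, gives 260 nM, and compound 3, `COc1cc(Sc2c[nH]c3ccc(O)cc23)cc(OC)c1OC`, gives 190 nM. The two exchanges at that aromatic carbon both weakened inhibition: a 3.4-fold higher number from compound 1 to compound 2 (0.53 log units; beyond the scatter) and a 2.5-fold higher number from compound 1 to compound 3 (0.39 log units; beyond the scatter), while a 1.4-fold lower number from compound 2 to compound 3 (0.14 log units; within the scatter).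

Compound 4, `COc1cc(Sc2c[nH]c3ccc(OCCOCc4ccccc4)cc23)cc(OC)c1OC`, differs from compound 1 in one place: 2-(benzyloxy)ethoxy in place of chloro on an aromatic carbon. The step from compound 1 to compound 3 bears most directly on it, since both put an oxygen-linked group where the chloro stood, and that step was modest. The step from compound 1 to compound 2 points the same way. A modest rise is therefore expected in this assay, a 2.9-fold higher number from compound 1 to compound 4 (0.46 log units; beyond the scatter), though the far larger group widens the uncertainty. Compound 4 is estimated at 220 nM, with a range from 60 nM to 800 nM.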

Compound 4, half-maximal inhibitory concentration: 260 nM
For compound 4 the middle estimate is 1.2-fold (0.07 log units) below the measured one; the measured number falls inside the stated range.
By their numbers in this assay, from the lowest: compound 1; then compounds 3, 2 and 4 (each within the scatter of the next).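

In this assay, going by these compounds alone, this aromatic carbon accepts a much larger group than the earlier compounds carried: with 11 heavy atoms and a six-membered aromatic ring entering where one chlorine left, the step stays modest (a 3.4-fold higher number from compound 1 to compound 4 (0.53 log units; beyond the scatter)). Placing 2-(benzyloxy)ethyl on the oxygen of the hydroxy group has no effect beyond the scatter (a 1.4-fold higher number from compound 3 to compound 4 (0.14 log units; within the scatter)), and neither does 2-(benzyloxy)ethoxy in place of amino (no change at the digits printed from compound 2 to compound 4 (within the scatter)). Compounds 2, 3 and 4 thus lie within the scatter of one another despite their very different groups, and only the chloro of compound 1 stands apart.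

Nothing in the data shown accounts for the chloro group's lower number. As far as these compounds go, whether a bromo, a methoxy or a carboxylic acid at this carbon would fall with compound 1 or with the other three remains open.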